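Cytotoxicity across side-chain variants of a shared core

The compounds below may be only part of what the source reports. "The series", "measured", "known", "first", "only" and "open" are said of these compounds alone.

Of the compounds shown here, three built on one core have been measured in a functional assay on MT2 cells (Homo sapiens) for cytotoxicity, read by MTT assay; on this read-out higher numbers stand for lower toxicity in this test and lower numbers for higher toxicity in this test. Compound 1 `CC(C)=CCOc1cc(Nc2nccs2)ccc1Cl` gives 26000 nM in this assay. Compound 2 `Clc1ccc(Nc2nccs2)cc1OCc1cccs1` gives 38000 nM. Compound 3 `Clc1ccc(Nc2nccs2)cc1OCc1nccs1` gives 20000 nM. Compound 3 carries the smallest of the three numbers, yet its nearest neighbour is compound 1 with a 1.3-fold lower number from compound 1 to compound 3 (0.11 log units; within the scatter) and its furthest is compound 2 with a 1.9-fold lower number from compound 2 to compound 3 (0.28 log units; within the scatter); neither gap reaches beyond the scatter, so no ranking of the three is supported. The remaining comparison, a 1.5-fold higher number from compound 1 to compound 2 (0.16 log units; within the scatter), is likewise within the scatter.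

Compound 4 `Clc1ccc(Nc2nccs2)cc1OCC1=CCCC1` has not been measured. It differs from compound 3 as follows: cyclopent-1-en-1-yl in place of 1,3-thiazol-2-yl on a saturated chain carbon bound to an oxygen on an aromatic ring. This change sits at the same place as the three measured steps, each of which exchanged one group on the saturated chain carbon bound to an oxygen on an aromatic ring, and each of which stayed within the scatter. Nothing in the series therefore points to a step beyond the scatter in this assay, in either direction. Compound 4 is estimated at 25000 nM, with a range from 10000 nM to 60000 nM. The expected step is a 1.3-fold higher number from compound 3 to compound 4 (0.10 log units; within the scatter), anticipated to stay within the usual spread.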

Compound 4, half-maximal cytotoxic concentration: 15000 nM
Estimate against measurement, compound 4: 1.7-fold (0.22 log units) above; the range from low to high includes it.
By their numbers in this assay, from the lowest: compounds 4, 3, 1 and 2 (each within the scatter of the next, the first and the last beyond it).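

In this assay, the saturated chain carbon bound to an oxygen on an aromatic ring gives its first step beyond the scatter, a modest one, with cyclopent-1-en-1-yl in place of thiophen-2-yl (a 2.5-fold lower number from compound 2 to compound 4 (0.40 log units; beyond the scatter)). The same entering group gives no separation from the other two groups, with one step in place of 1,3-thiazol-2-yl (a 1.3-fold lower number from compound 3 to compound 4 (0.12 log units; within the scatter)) and one in place of 2-methylprop-1-en-1-yl (a 1.7-fold lower number from compound 1 to compound 4 (0.24 log units; within the scatter)), both within the scatter. Exchanging an aromatic five-membered ring for cyclopent-1-en-1-yl therefore does not go with a separation in every case, and compound 4 stands apart from compound 2 only, while compound 3 remains within the scatter of both.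

Within the data shown here, no measurement at hand bears on what lies behind the single step beyond the scatter. Going by these compounds, whether an amine, a carboxylic acid or a longer chain on this chain carbon would give a larger step remains open.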